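This account rests on a few compounds, and the source may have more. Where it says the series, first, only, none or still open, it means among the compounds named here.

Of the compounds shown here, three carrying a shared amide core have been measured in a physicochemical assay for solubility, measured as kinetic solubility, with a stated time of 1 h, at pH 7.4; on this read-out lower numbers stand for lower solubility and higher numbers for higher solubility. Compound 1 `N#CCC(=O)Nc1nc(-c2ccc(Cl)c(Cl)c2)cs1` gives 57000 nM in this assay. Compound 2 `CC(=O)Nc1nc(-c2ccc(Cl)c(C)c2)cs1` gives 1000 nM. Compound 3 `N#CCC(=O)NC1=NN(c2ccc(Cl)c(Cl)c2)CC1`, whose core differs from that of the first two, gives 202000 nM and stands highest of the three numbers: the nearest of the other two is compound 1, at a lower figure, a gap beyond the usual scatter, and the furthest is compound 2, lower still, likewise beyond the scatter.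

The account now turns from compound 3 to compound 4 `O=C(NC1=NN(c2ccc(Cl)c(Cl)c2)CC1)c1ccnnc1`, which has not yet been measured in this assay. The structural change between them is pyridazin-4-yl in place of cyanomethyl on a carbonyl carbon. For the measured compounds named here, no step between measured compounds of this kind is available, so its effect can only be anticipated. Going by the values given here, because compound 3 already sits at 202000 nM, the highest of the numbers so far, a moderate decrease is expected, with the change estimated at a 2.9-fold lower number from compound 3 to compound 4 (0.46 log units; beyond the scatter), a step beyond the scatter but well short of the gap that separates compound 3 from compound 2. Compound 4 is therefore expected to give about 70000 nM in this assay, with a likely range from 20000 nM to 200000 nM.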

Compound 4, solubility: 23000 nM
Compound 4: middle estimate off by 3.0-fold (0.48 log units), on the high side, and the stated range covers the measured number.
By their numbers in this assay, from the lowest: compound 2; then compound 4; then compound 1; then compound 3.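

In this assay, for the compounds shown here, the exchange of cyanomethyl for pyridazin-4-yl on a carbonyl carbon brings an 8.8-fold lower number from compound 3 to compound 4 (0.94 log units; beyond the scatter), the first reading of a change at a single place, and it shows that the number responds to the group carried at this position. The step is confined to this one pair, and with the six-membered aromatic ring in place of the open chain, compound 4 gives 23000 nM. Nothing at hand bears on why the number falls with this exchange.

The compounds shown leave open whether the step belongs to the aromatic ring as such or to its ring nitrogens, a question that a phenyl group on the same carbonyl carbon would address, and how a longer chain ending in an amine or a carboxylic acid would compare with cyanomethyl there. They also leave open whether pyridazin-4-yl in place of cyanomethyl would move the number in the same direction and by a similar size on the core of compound 1.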